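A few compounds are considered here, and "the series" means these few. Any claim that something is new, unique, unknown or untested is made for them only; others in the source may bear on it.

Measured so far:
- compound 1 `COc1cc(-c2ccnc3cc(-c4cn(CO)c5ccccc45)nn23)cc(OC)c1OC` gives 167 nM
- compound 2 `COc1cc(-c2cc3nccc(-c4c[nH]c5ccccc45)n3n2)cc(OC)c1OC` gives only a limit, > 10000 nM
- compound 3 `COc1cc(-c2ccnc3cc(-c4cccc(C#N)c4)nn23)cc(OC)c1OC` gives only a limit, > 10000 nM

Within the data shown here, in a functional assay on A549 cells (Homo sapiens) for inhibition, read by CCK-8 assay, with a stated time of 48 h (a lower number here means a stronger inhibitor, a higher number a weaker inhibitor), compound 1 gives 167 nM, the only numerical value among the three. For compound 2 the assay reports only its limit, > 10000 nM. For compound 3 the assay likewise reports only its limit, > 10000 nM. Two of the three values shown sit at that limit (the limit of > 10000 nM in this assay, at which 2 of the 3 values shown sit), so compound 3 stands at the inactive edge of what is shown, and no number places it relative to compound 2.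

Compound 4 `COc1cc(-c2ccnc3cc(-c4ccc(C(C)=O)cc4)nn23)cc(OC)c1OC` differs from compound 3 in one place: 4-acetylphenyl in place of 3-cyanophenyl on an aromatic carbon. No measured step joins any two of the compounds shown, so the effect of this change cannot be read from a neighbour. The expected step of an at least 1.2-fold lower number from compound 3 to compound 4 (0.09 log units; that floor lies within the scatter) is estimated to be none beyond the scatter, with a fair chance that this assay again returns only a limit. Compound 4 is estimated at 8000 nM, with a range from 2000 nM to 30000 nM.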

Compound 4, half-maximal inhibitory concentration: 4100 nM
Compound 4: middle estimate off by 2.0-fold (0.29 log units), on the high side; measured number inside the range.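

In this assay, 4-acetylphenyl in place of 3-cyanophenyl gives an at least 2.4-fold lower number from compound 3 to compound 4 (0.38 log units; beyond the scatter), so a substituted phenyl on this aromatic carbon, two ring bonds from the ring nitrogen, can return a measured number rather than a limit. Compound 3 has only a limit, and the step is therefore a floor with its full size unknown because of that limit: the limit of > 10000 nM in this assay, at which 2 of the 4 values shown sit. Compound 4 gives 4100 nM, a higher number than compound 1 at 167 nM, so this phenyl group does not match the printed value of the group in compound 1.

The step changes both the substituent and its place on the phenyl ring, and the two effects cannot be separated here. A 4-cyanophenyl or 3-acetylphenyl group would separate them, and a 4-aminophenyl or 4-carboxyphenyl group would test other substituents at this place.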